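Swapping the aryl group on a sulfonamide-diamine chain

The source may report more compounds than this note shows. Statements on the series, on what has been measured and on what is new or still open speak of the compounds shown alone.

Compound 3 `O=S(=O)(NCCCNCc1ccc(Cl)c(C(F)(F)F)c1)c1cc(C(F)(F)F)cc(C(F)(F)F)c1` was tested in a functional assay on HT-29 cells (Homo sapiens) for inhibition, read by MTT assay, with a stated time of 72 h (a lower number here means a stronger inhibitor of growth, a higher number a weaker inhibitor of growth), and gives 11000 nM. Among the three compounds measured, compound 3 has the second highest number. Compound 1 `O=S(=O)(NCCNCc1cccc2ccccc12)c1cc(C(F)(F)F)cc(C(F)(F)F)c1` gives 16000 nM in this assay, and its gap to compound 3 lies within the scatter. Compound 2 `O=S(=O)(NCCNCc1ccc(-c2ccccc2)cc1)c1cc(C(F)(F)F)cc(C(F)(F)F)c1` gives 2700 nM in this assay, a gap from compound 3 that lies beyond the scatter.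

Compound 4 `COc1ccc(CNCCCNS(=O)(=O)c2cc(C(F)(F)F)cc(C(F)(F)F)c2)cc1` has not yet been measured. It differs from compound 3 by 4-methoxyphenyl in place of 4-chloro-3-(trifluoromethyl)phenyl on a saturated chain carbon bound to an amine nitrogen. Among the measured compounds shown here, no pair of measured compounds shows this change in isolation, so there is no measured step to lean on. The three measured values all sit in a narrow, weak range, and the change keeps the shared core and the chain intact. The step from compound 3 to compound 4 in this assay is therefore expected to be small, a 1.4-fold higher number from compound 3 to compound 4 (0.13 log units; within the scatter), with no clear direction beyond the scatter. Compound 4 is estimated at 15000 nM in this assay, within a range from 5000 nM to 40000 nM.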

Compound 4, concentration for 50% growth inhibition: 2900 nM
Compound 4: the middle estimate sits 5.2-fold (0.71 log units) above what was measured; measured number outside the range, below it.
By their numbers in this assay, from the lowest: compounds 2 and 4 (each within the scatter of the next); then compounds 3 and 1 (each within the scatter of the next).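

In this assay, the aryl group on this saturated chain carbon bound to an amine nitrogen proves to matter: with the shared core and the chain unchanged, 4-methoxyphenyl in place of 4-chloro-3-(trifluoromethyl)phenyl gives a 3.8-fold lower number from compound 3 to compound 4 (0.58 log units; beyond the scatter). Among the compounds shown here, the earlier compounds offered no step that changed only one place, so this is the first direct sign that growth inhibition in these cells responds to this group. Nothing measured here explains why the number falls.

A single step cannot separate the arrival of the methoxy group from the loss of the chlorine and the trifluoromethyl group. From the compounds shown here alone, it also remains open how an unsubstituted phenyl group or a longer chain would read in this assay.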